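Replacing the methoxy of compound 1 with a silicon group

The source may hold more compounds than are shown below. What is called first, only, known or untested is meant among the compounds shown, and "the series" means these compounds.

Compound 1 `COC/C1=C/C[C@](C)(CCC=C(C)C)/C=C/[C@@H](OC(=O)C=C(C)C)[C@](C)(O)/C=C/C1=O` gives 11000 nM
Compound 2 `CC(=O)O[C@]1(C)/C=C/C(=O)/C(CO)=C\C[C@](C)(CCC=C(C)C)/C=C/[C@H]1OC(=O)C=C(C)C` gives 3080 nM
Compound 3 `CO[C@]1(C)/C=C/C(=O)/C(CO)=C\C[C@](C)(CCC=C(C)C)/C=C/[C@H]1OC(=O)C=C(C)C` gives 15800 nM

In a functional assay on SMMC-7721 cells (Homo sapiens) for antiproliferative activity, read by MTT assay, with a stated time of 48 h (a lower number here means a stronger inhibitor, a higher number a weaker inhibitor), compound 1 lies within the scatter of compound 3 and above compound 2 by more than the scatter. Compound 4 `CC[Si](CC)(CC)C/C1=C/C[C@](C)(CCC=C(C)C)/C=C/[C@@H](OC(=O)C=C(C)C)[C@](C)(O)/C=C/C1=O` differs from compound 1 as follows: a group of 7 heavy atoms (6 carbon, 1 silicon; no ring) in place of a group of 2 heavy atoms (1 carbon, 1 oxygen; no ring), on a saturated chain carbon bound to a double-bonded ring carbon. For the measured compounds named here, no measured step touches this carbon. Going by the values given here, the only step, a 5.1-fold higher number from compound 2 to compound 3 (0.71 log units; beyond the scatter), concerns a different oxygen, so it shows only that a modest move is possible. From the compounds shown here alone, no shift beyond the scatter is therefore expected, and the direction stays open. The estimated change is a 1.4-fold lower number from compound 1 to compound 4 (0.14 log units; within the scatter) in this assay. For compound 4 the expected value is 8000 nM, with an estimated range of 2500 nM to 26000 nM in this assay.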

Compound 4, half-maximal inhibitory concentration: 3460 nM
For compound 4 the middle estimate is 2.3-fold (0.36 log units) above the measured one; low and high end bracket the measured number.
By their numbers in this assay, from the lowest: compounds 2 and 4 (each within the scatter of the next); then compounds 1 and 3 (each within the scatter of the next).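

In this assay, for the compounds shown here, the saturated chain carbon bound to a double-bonded ring carbon responds to substitution: the silicon group in place of methoxy gives a 3.2-fold lower number from compound 1 to compound 4 (0.50 log units; beyond the scatter), the first measured change at this carbon. The carbon therefore accepts a group of 7 heavy atoms without loss, and the hydrogen-bond acceptor of methoxy can go without loss in this assay. No measurement available here accounts for the shift. Open, from the compounds shown here alone, is whether the silicon atom itself matters. A longer all-carbon chain or an amine on this carbon would test that.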